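A few compounds are considered here, and "the series" means these few. Any claim that something is new, unique, unknown or untested is made for them only; others in the source may bear on it.

Compound 1 `COC(=O)c1cc(N)c(Nc2ccc(C#N)cc2)cc1Oc1c(C)cc(/C=C/C#N)cc1C` has the lowest number of the three measured compounds in an in vitro ADME assay on microsomes from liver (Homo sapiens) for metabolic stability, tested at 1 uM (a lower number here means slower removal, a higher number faster removal of the compound), where compound 1 gives 20 mL.min-1.g-1. Compound 2 `Cc1cc(/C=C/C#N)cc(C)c1Oc1cc(Nc2ccc(C#N)cc2)c(N)cc1C(F)(F)F` carries a trifluoromethyl group on an aromatic carbon in place of the methoxycarbonyl group, and in this assay compound 2 gives 150 mL.min-1.g-1, a step of a 7.5-fold higher number from compound 1 to compound 2 (0.88 log units; beyond the scatter). Compound 3 `Cc1cc(CCC#N)cc(C)c1Oc1cc(Nc2ccc(C#N)cc2)c(N)cc1C(N)=O` carries a carbamoyl group and a saturated three-carbon nitrile chain, and in this assay compound 3 gives 160 mL.min-1.g-1.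

Compound 4 `Cc1cc(/C=C/C#N)cc(C)c1Oc1cc(Nc2ccc(C#N)cc2)c(N)cc1C(N)=O` is compound 1 with one change: amino in place of methoxy on a carbonyl carbon. Among the compounds with values here, no measured step covers exactly this change. Within the data shown here, the only step that starts from compound 1 replaces the whole methoxycarbonyl group and gives a modest rise, while compound 3, which shares the carbamoyl group of compound 4 but differs in a second place, shows a number far above that of compound 1. Both point the same way, so a rise beyond the scatter is expected, though its size is uncertain. In this assay compound 4 is expected to give about 80 mL.min-1.g-1, within a range of 30 mL.min-1.g-1 to 220 mL.min-1.g-1. This corresponds to an expected step of a 4.0-fold higher number from compound 1 to compound 4 (0.60 log units; beyond the scatter).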

Compound 4, intrinsic clearance in microsomes in the Homo sapiens assay: 200 mL.min-1.g-1
For compound 4 the middle estimate is 2.5-fold (0.40 log units) below the measured one; the measured number falls inside the stated range.
By their numbers in the Homo sapiens assay, from the lowest: compound 1; then compounds 2, 3 and 4 (each within the scatter of the next).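

Changing only the methoxy to amino on the carbonyl carbon is enough to move the number in the Homo sapiens assay, giving a 10-fold higher number from compound 1 to compound 4 (1.00 log units; beyond the scatter), so the low number of compound 1 depends on the methoxycarbonyl group in a comparison where just those atoms differ. Carbamoyl in place of trifluoromethyl gives a 1.3-fold higher number from compound 2 to compound 4 (0.12 log units; within the scatter), and 2-cyanoethenyl in place of 2-cyanoethyl gives a 1.3-fold higher number from compound 3 to compound 4 (0.10 log units; within the scatter), so neither of these two changes separates its pair, and in both single-place comparisons that start from compound 1 the methoxycarbonyl compound stands apart. In a physicochemical assay for solubility, with a stated time of 4 h, at pH 7.4 (a higher number here means a more soluble compound, a lower number a less soluble compound), compound 1 gives 1.3 ug/mL and compound 4 gives 0.63 ug/mL, so the change that raises the clearance number also goes with lower solubility, and the amide offers no gain on that side: the measured solubility of compound 1, 1.3 ug/mL, and of compound 4, 0.63 ug/mL, a 2.1-fold lower number (0.31 log units; beyond the scatter)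

As far as these compounds go, how an ethyl ester, a carboxylic acid or a methylamide on the same carbonyl carbon would read in the Homo sapiens assay stays open, and these would show whether the low number belongs to the methoxy alone or to a wider set of groups. Also open, from the compounds shown here alone, is whether methoxycarbonyl would keep its low number with 2-cyanoethyl in place of 2-cyanoethenyl on the shared core.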